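Methoxy to hydrogen in two ester pairs: working notes

This account rests on a few compounds, and the source may have more. Where it says the series, first, only, none or still open, it means among the compounds named here.

Measured so far in a functional assay on EA.hy 926 cells (Homo sapiens) for cytotoxicity, read by MTT assay, with stated times of 24 h and 12 h, tested at 50 uM; a higher number here means a stronger effect of the compound at the concentration tested, a lower number a weaker effect:
compound 1, `Cc1nc(C)c(C(=O)Oc2ccccc2/C=C/C(=O)O)nc1C`, 64.9%
compound 2, `COc1ccc(/C=C/C(=O)O)c(OC(=O)c2nc(C)c(C)nc2C)c1`, 31.6%
compound 3, `CCOC(=O)/C=C/c1ccc(OC(=O)c2nc(C)c(C)nc2C)c(OC)c1`, 69.7%

Compounds 2 and 1 differ in one place, (hydrogen in place of methoxy on an aromatic carbon), and the change gives a number 33.3 percentage points higher from compound 2 to compound 1 (beyond the scatter). Compound 3 gives the highest of the three numbers, yet its gap to compound 1 lies within the scatter, while its gap to compound 2 lies beyond it; the difference between the cores of compound 3 and compound 2 is not broken down here.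

Compound 4, `CCOC(=O)/C=C/c1ccc(OC(=O)c2nc(C)c(C)nc2C)cc1`, is not yet measured in this assay. It differs from compound 3 by hydrogen in place of methoxy on an aromatic carbon. The change is the same kind of change as that from compound 2 to compound 1, not the same: in the earlier pair the site was meta to a large group and para to a 2-carboxyethenyl group, here it is ortho to a large group and meta to a 2-(ethoxycarbonyl)ethenyl group.

Within the data shown here, a rise is expected for compound 4, because the one precedent a number 33.3 percentage points higher from compound 2 to compound 1 (beyond the scatter) points upward, but compound 3 already stands high, so a smaller step is expected: a number 6.3 percentage points higher from compound 3 to compound 4 (within the scatter). Compound 4 is estimated at 76% in this assay, with a range from 62% to 90% expected.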

Compound 4, a percentage reported as activity, at one concentration (the size of the read-out at that concentration, not a potency): 62.6%
The estimate for compound 4 lay 13.4 percentage points above the measured number; low and high end bracket the measured number.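

In this assay, among these compounds, hydrogen in place of methoxy on the core of compound 3 gives a number 7.1 percentage points lower from compound 3 to compound 4 (within the scatter), so this pair shows no step that can be told from the scatter. The change therefore does not carry over at one size from one core to the other: the same change on two cores in this assay, a number 33.3 percentage points higher (beyond the scatter) from compound 2 to compound 1 and a number 7.1 percentage points lower (within the scatter) from compound 3 to compound 4, 40.4 percentage points apart, beyond the scatter of two such steps. Among the compounds shown here, this shows that the large step from the first pair cannot be assumed on the second core, but with only two pairs it gives no rule for a third core, and it does not show what sets the two steps apart, since the pairs differ both in the site of the methoxy and in carrying a 2-carboxyethenyl group or a 2-(ethoxycarbonyl)ethenyl group.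

The compounds shown leave open whether the dependence on the core belongs to methoxy alone or would also appear with another group at the same place, such as an amine, fluorine or a longer alkoxy chain. They also leave open how the two cores would compare if the ethyl ester gave way to a carboxylic acid with the methoxy site held fixed, and each read-out here remains a size at one concentration, not a potency.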